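The source may report more compounds than this note shows. Statements on the series, on what has been measured and on what is new or still open speak of the compounds shown alone.

Compound 1, `CC(C)(C)OC(=O)N1CCN(C(=S)SCc2cn(-c3ccccc3F)nn2)CC1`, and compound 2, `O=C(OCc1ccccc1)N1CCN(C(=S)SCc2cn(Cc3ccc(F)cc3)nn2)CC1`, share a core and were both tested in a functional assay on ECa-109 cells (Homo sapiens) for inhibition, read by MTT assay, with a stated time of 72 h; a lower number here means a stronger inhibitor, a higher number a weaker inhibitor. For compound 1 this assay reports only a limit, > 128000 nM, not a number. Where compound 1 stands is therefore set by the limit of > 128000 nM in this assay, at which 1 of the 2 values shown sits, alone. Compound 2 gives 32000 nM in this assay. Among the measured compounds shown here, compounds 1 and 2 differ in more than one place, so no single step between them is set out; their two values show only that compound 2 yields a number where compound 1 yields a limit.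

Compound 3, `Cc1ccc(-n2cc(CSC(=S)N3CCN(C(=O)OC(C)(C)C)CC3)nn2)cc1`, has not yet been measured. It differs from compound 1 by 4-methylphenyl in place of 2-fluorophenyl on an aromatic nitrogen: the 2-fluorophenyl leaves and a 4-methylphenyl enters on an aromatic nitrogen of the five-membered ring.

Since compound 1 sits at a limit, no measured step sizes the change. One substituted phenyl on an aromatic nitrogen replacing another is expected to shift potency little, if at all beyond the scatter, and the expected step is an at least 1.2-fold lower number from compound 1 to compound 3 (0.10 log units; that floor lies within the scatter). Compound 3 is thus estimated at 100000 nM, within 30000 nM to 300000 nM, with a real chance this assay again reports only a limit.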

Compound 3, half-maximal inhibitory concentration: 114000 nM
Estimate against measurement, compound 3: 1.1-fold (0.06 log units) below, and the stated range covers the measured number.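

Among the compounds shown here, the exchange of 2-fluorophenyl for 4-methylphenyl on an aromatic nitrogen gives an at least 1.1-fold lower number from compound 1 to compound 3 (0.05 log units; that floor lies within the scatter) in this assay, the first step at this position that can be read, though only as a floor. Compound 1 remains a limit and not a number, so the step is bounded from one side only: the limit of > 128000 nM in this assay, at which 1 of the 3 values shown sits. With the rest of the structure unchanged, compound 3 gives 114000 nM, which shows that a substituted phenyl at this position can yield a number in this assay.

As far as these compounds go, the true size of the step stays open, and so does whether any replacement on this nitrogen can move the value beyond the scatter. The compounds shown also leave open how an amine, a carboxylic acid or a longer alkyl chain in this place would read in this assay, and whether the same exchange would give a similar step with the other end of the molecule changed.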